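This account rests on a few compounds, and the source may have more. Where it says the series, first, only, none or still open, it means among the compounds named here.

Three compounds measured in a functional assay on RKOp27 cells (Homo sapiens) for cytotoxicity, read by MTT assay, with a stated time of 3 days (on this read-out higher numbers stand for weaker inhibition and lower numbers for stronger inhibition), so far:
- compound 1 `N#Cc1c(Cl)nc(SCc2nc3ccccc3[nH]2)nc1-c1ccccc1` gives 4.38 nM
- compound 2 `N#Cc1c(Nc2ccccn2)nc(SCc2nc3ccccc3[nH]2)nc1-c1ccccc1` gives 3.8 nM
- compound 3 `N#Cc1c(NC(N)=O)nc(SCc2nc3ccccc3[nH]2)nc1-c1ccccc1` gives 2.5 nM

Compound 2 at 3.8 nM sits among the three numbers, but it cannot be told apart from the other two. Compound 4 `CN1CCN(c2nc(SCc3nc4ccccc4[nH]3)nc(-c3ccccc3)c2C#N)CC1` differs from it in one place: 4-methylpiperazin-1-yl in place of (pyridin-2-yl)amino on an aromatic carbon. Here 4-methylpiperazin-1-yl stands in place of (pyridin-2-yl)amino on an aromatic carbon, ortho to a cyano group.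

The measured steps at this same carbon bear directly on the change. They are a 1.2-fold lower number from compound 1 to compound 2 (0.06 log units; within the scatter), a 1.8-fold lower number from compound 1 to compound 3 (0.24 log units; within the scatter) and a 1.5-fold lower number from compound 2 to compound 3 (0.18 log units; within the scatter), and all lie within the scatter. Three different groups at this carbon have so far made no clear difference. None of them brings a non-aromatic ring, however, so the range stays wide. No step beyond the scatter is expected in this assay, in either direction.

The estimated step is a 1.1-fold higher number from compound 2 to compound 4 (0.02 log units; within the scatter) and it would be too small to read as a real change. For compound 4 the expected value is 4 nM, with an estimated range from 1.5 nM to 12 nM.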

Compound 4, half-maximal inhibitory concentration: 5.4 nM
Compound 4: middle estimate off by 1.4-fold (0.13 log units), on the low side; the measured number falls inside the stated range.
By their numbers in this assay, from the lowest: compounds 3, 2, 1 and 4 (each within the scatter of the next, the first and the last beyond it).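

In this assay, the 4-methylpiperazin-1-yl group brings the first non-aromatic ring to this carbon, and the steps of a 1.4-fold higher number from compound 2 to compound 4 (0.15 log units; within the scatter) and a 1.2-fold higher number from compound 1 to compound 4 (0.09 log units; within the scatter) show no clear difference from the (pyridin-2-yl)amino or chloro groups. Against the ureido group, however, a 2.2-fold higher number from compound 3 to compound 4 (0.33 log units; beyond the scatter) is the first step at this carbon to pass beyond the scatter, though only modestly. The four groups therefore give close numbers at this carbon, and the gap between compound 3 and compound 4 is the one exception.

As far as these compounds go, whether a carboxylic acid or a longer open chain at this carbon would keep the number in this range remains open. Nothing measured here explains why these groups give such close numbers or why compound 3 and compound 4 stand apart.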